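The compounds below may be only part of what the source reports. "The series", "measured", "known", "first", "only" and "open" are said of these compounds alone.

Compound 1, `COc1c(OC)c(OC(C)=O)c2c(Cl)cccc2c1OC(C)=O`, was measured in a physicochemical assay for lipophilicity (on this read-out lower numbers stand for lower lipophilicity and higher numbers for higher lipophilicity), where compound 1 gives 3.16. Compound 3, `COc1c(OC)c(OC(C)=O)c2c(OC)cccc2c1OC(C)=O`, shares the core of compound 1 and differs from it in a single place: methoxy in place of chloro on an aromatic carbon. In this assay compound 3 gives 2.43, and the step of a number 0.73 log units lower from compound 1 to compound 3 (beyond the scatter) is one of the two such changes seen among these compounds.

Compound 2, `CCC(=O)Oc1c(OC)c(OC)c(OC(=O)CC)c2cc(Cl)ccc12`, carries a different core; how the two cores differ is not broken down here. In this assay compound 2 gives 4.3, the highest of the three numbers.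

Compound 4, `CCC(=O)Oc1c(OC)c(OC)c(OC(=O)CC)c2cc(OC)ccc12`, has not yet been measured. It differs from compound 2 in one place: methoxy in place of chloro on an aromatic carbon. Around the place, the change in compound 3 sits ortho to a fused ring and meta to a fused ring, whereas in compound 4 it sits meta to a fused ring and para to a fused ring, so it is the same kind of change rather than the same change. Compound 4 is expected to show a step of about a number 0.73 log units lower from compound 2 to compound 4 (beyond the scatter), a size that rests on the earlier step of a number 0.73 log units lower from compound 1 to compound 3 (beyond the scatter) in compound 3. Compound 4 is thus estimated at 3.57, with a likely range from 3.2 to 3.95.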

Compound 4, partition coefficient: 3.28
Compound 4: the middle estimate sits 0.29 log units above what was measured; the measured number falls inside the stated range.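

In this assay the replacement of chloro by methoxy on an aromatic carbon lowers the number again, with a number 1.02 log units lower from compound 2 to compound 4 (beyond the scatter) and with both this step and a number 0.73 log units lower from compound 1 to compound 3 (beyond the scatter) lying beyond the scatter, so the direction of the change carries over from the core of compound 1 to the core of compound 2. Going by these compounds alone, these are only two pairs, and the place of the change differs between them, so they do not fix one size for the change and cannot separate the part played by the core from the part played by the place. No available information bears on why the two steps take the sizes they do.

The compounds shown leave open whether the same direction would hold if an amine or a carboxylic acid took the place of methoxy on either core. They also leave open how the change would read with a longer chain in place of the methoxy methyl.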